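A few compounds are considered here, and "the series" means these few. Any claim that something is new, unique, unknown or untested is made for them only; others in the source may bear on it.

Measured compounds in a functional assay for antagonist activity at 5-hydroxytryptamine receptor 4 (Rattus norvegicus); on this read-out lower numbers stand for lower potency and higher numbers for higher potency (the scale is a negative logarithm):
- compound 1, `COc1cc(COc2cc(N)c(Cl)cc2C(=O)CCCCN2CCCCC2)cc(OC)c1`: 8.5
- compound 2, `CCCC1CCN(CCCCC(=O)c2cc(Cl)c(N)cc2OCc2cc(OC)cc(OC)c2)CC1`: 7.7
- compound 3, `COc1cc(COc2cc(N)c(Cl)cc2C(=O)CCCCN2CCC(O)CC2)cc(OC)c1`: 8.3

All three share one core and differ only in the group on the saturated ring carbon of the six-membered ring that holds the nitrogen. Compound 3, which carries a hydroxy there, stands close to compound 1: the step of a number 0.20 log units lower from compound 1 to compound 3 (within the scatter) lies within the scatter, so the two cannot be told apart on these numbers. Against compound 2, however, the step of a number 0.60 log units higher from compound 2 to compound 3 (beyond the scatter) is beyond the scatter, and the related step of a number 0.80 log units lower from compound 1 to compound 2 (beyond the scatter) shows the same thing from the other side: a propyl at this position costs potency, while a hydroxy does not.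

Compound 4, `COc1cc(COc2cc(N)c(Cl)cc2C(=O)CCCCN2CCC(C(N)=O)CC2)cc(OC)c1`, takes the next step: carbamoyl in place of hydroxy on a saturated ring carbon. Of the measured steps, only the ones at this same ring carbon bear on it. A larger group there (propyl) lowered the number by a modest amount, whereas a small group (hydroxy) left it essentially unchanged. Carbamoyl is larger than hydroxy, so a small loss, at most modest, is expected in this assay, namely a number 0.30 log units lower from compound 3 to compound 4 (within the scatter). Compound 4 is therefore estimated at 8, with a likely range from 7.4 to 8.6.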

Compound 4, negative logarithm of the antagonist equilibrium constant: 8.4
Compound 4: the middle estimate sits 0.40 log units below what was measured; measured number inside the range.
By their numbers in this assay, from the lowest: compound 2; then compounds 3, 4 and 1 (each within the scatter of the next).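

In this assay, the change from hydroxy to carbamoyl is a step of a number 0.10 log units higher from compound 3 to compound 4 (within the scatter), and putting carbamoyl in place of hydrogen is a step of a number 0.10 log units lower from compound 1 to compound 4 (within the scatter), so this ring carbon accepts carbamoyl with no measurable change from either neighbour. Before this result, propyl was the only group shown to lower the number, and a larger group might have been expected to do the same; carbamoyl, with more heavy atoms than hydroxy, does not, as the step of a number 0.70 log units higher from compound 2 to compound 4 (beyond the scatter) makes plain, which leaves propyl as the only group shown here that lowers the number. Nothing available explains why propyl and carbamoyl part ways at this position.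

As far as these compounds go, it remains open whether an amine, a carboxylic acid or a butyl chain on this ring carbon would behave like carbamoyl or like propyl. A methyl, or an ethyl chain, would also show whether the loss seen with propyl already appears with a shorter chain.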